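Swapping the Amide Group on Compound 2

This account rests on a few compounds, and the source may have more. Where it says the series, first, only, none or still open, it means among the compounds named here.

Compound 1 `COc1cc([C@@H]2C[C@]2(CO)C(=O)Nc2ccccc2Cl)cc(OC)c1OC`: 13200 nM
Compound 2 `CCOC(=O)[C@]1(C(=O)NCc2ccc(C)cc2)C[C@H]1c1cc(OC)c(OC)c(OC)c1`: 36400 nM

In a functional assay on SW480 cells (Homo sapiens) for cytotoxicity, read by MTT assay, with a stated time of 48 h (on this read-out higher numbers stand for weaker inhibition and lower numbers for stronger inhibition), compound 2 gives 36400 nM, the higher of the two numbers and so the weaker result. Its gap to compound 1 lies beyond the usual scatter. Compound 3 `CCOC(=O)[C@]1(C(=O)Nc2ccccc2Cl)C[C@H]1c1cc(OC)c(OC)c(OC)c1` has not yet been measured. It carries 2-chlorophenyl in place of 4-methylbenzyl on an amide-type nitrogen. Within the data shown here, no measured pair shows this change alone, so any forecast is rough. Compound 1, at 13200 nM, also carries 2-chlorophenyl on an amide-type nitrogen, which points to a small move toward lower numbers in this assay, perhaps no larger than the scatter. The expected change is a 1.8-fold lower number from compound 2 to compound 3 (0.26 log units; within the scatter). The estimated value for compound 3 is 20000 nM, with an expected range of 7000 nM to 60000 nM.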

Compound 3, half-maximal inhibitory concentration: 25600 nM
Compound 3: middle estimate off by 1.3-fold (0.11 log units), on the low side, within the range that was stated.
By their numbers in this assay, from the lowest: compounds 1, 3 and 2 (each within the scatter of the next, the first and the last beyond it).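

On the amide-type nitrogen, 2-chlorophenyl in place of 4-methylbenzyl gives a 1.4-fold lower number from compound 2 to compound 3 (0.15 log units; within the scatter) in this assay, so this position accepts the swap without a clear shift in the read-out. On the saturated ring carbon, ethoxycarbonyl in place of hydroxymethyl gives a 1.9-fold higher number from compound 1 to compound 3 (0.29 log units; within the scatter) in this assay, so neither single change, taken alone, moves the number beyond the scatter. No supporting measurement is available to explain either result.

The swap on the nitrogen alters the ring's substituent and removes the carbon linking ring to nitrogen in one step, so these two differences cannot be told apart here. From the compounds shown here alone, it remains open whether a plain phenyl on that nitrogen, or a carboxylic acid on the saturated ring carbon, would give a step beyond the scatter.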